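The compounds below may be only part of what the source reports. "The series", "measured", "known", "first", "only" and "open" are said of these compounds alone.

Among the measured compounds shown here, compound 2 `O=C1N=C(N2N=C(c3ccccc3)CC2c2ccccc2O)S/C1=C1/C(=O)Nc2ccc(Br)cc21` stands lowest of the two numbers in a functional assay on cells (Cancer cell lines, Homo sapiens) for cytotoxicity, read by sulforhodamine B assay, with a stated time of 48 h; a higher number here means a weaker inhibitor of growth, a lower number a stronger inhibitor of growth: compound 2 gives 720 nM, while compound 1 `O=C1N=C(N2N=C(c3ccccc3)CC2c2ccccc2O)S/C1=C1/C(=O)Nc2ccccc21` gives 5370 nM; this is the one measured step, a 7.5-fold lower number from compound 1 to compound 2 (0.87 log units; beyond the scatter), a bromo in place of hydrogen on the fused ring. Compound 3 `CN(C)c1ccc(C2CC(c3ccccc3)=NN2C2=NC(=O)/C(=C3\C(=O)Nc4ccc(Br)cc43)S2)cc1` differs from compound 2 by 4-(dimethylamino)phenyl in place of 2-hydroxyphenyl on a saturated ring carbon. For the measured compounds named here, no measured step touches this saturated ring carbon, so the bromo step offers no direct guide. Compound 3 is therefore expected to sit near compound 2, with a step of a 1.3-fold higher number from compound 2 to compound 3 (0.10 log units; within the scatter) not expected beyond the scatter. Compound 3 is estimated at 900 nM, within 300 nM to 3000 nM.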

Compound 3, concentration for total growth inhibition: 450 nM
The estimate for compound 3 lay 2.0-fold (0.30 log units) above the measured number; low and high end bracket the measured number.
By their numbers in this assay, from the lowest: compounds 3 and 2 (each within the scatter of the next); then compound 1.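

In this assay, among the compounds shown here, the saturated ring carbon accepts 4-(dimethylamino)phenyl in place of 2-hydroxyphenyl, with a 1.6-fold lower number from compound 2 to compound 3 (0.20 log units; within the scatter) as the only reading at this position. The entering group has 0 hydrogen-bond donors against 1 in the group that leaves, so the hydroxy group of compound 2 is not required for a number in this range. No measurement bears on why these two groups read alike.

As far as these compounds go, a carboxylic acid or a longer chain at this carbon remains open. So does the effect of 4-(dimethylamino)phenyl on the core of compound 1, without the bromo group.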